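A few compounds are considered here, and "the series" means these few. Any claim that something is new, unique, unknown or untested is made for them only; others in the source may bear on it.

Measured compounds in an ADME assay on J774.A1 cells (Mus musculus) for cytotoxicity, read by MTT assay, with a stated time of 72 h; on this read-out lower numbers stand for higher toxicity in this test and higher numbers for lower toxicity in this test:
- compound 1 `CC1(c2ccc(-c3ccccc3C#N)cc2)CC(S(=O)(=O)c2ccc(F)cc2)=C(c2ccc(/C(N)=N\O)cc2)O1` gives 9290 nM
- compound 2 `CC1(Cc2ccccc2)CC(S(=O)(=O)c2c(F)cccc2F)=C(c2ccc(/C(N)=N\O)cc2)O1` gives 27000 nM
- compound 3 `CC1(Cc2ccccc2)CC(S(=O)(=O)c2ccccc2C(F)(F)F)=C(c2ccc(/C(N)=N\O)cc2)O1` gives 23500 nM

Among these three numbers, compound 1 stands lowest, which on this read-out marks it as the most toxic of the three; the numbers for compound 2 and compound 3 lie beyond the scatter above it. Compound 4 `Cc1ccc(-c2ccc(C3(C)CC(S(=O)(=O)c4ccc(F)cc4)=C(c4ccc(/C(N)=N\O)cc4)O3)cc2)cc1` has not yet been measured in this assay. It differs from compound 1 in one place: 4-methylphenyl in place of 2-cyanophenyl on an aromatic carbon.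

Among the measured compounds shown here, only one measured pair differs in a single place: a 1.1-fold lower number from compound 2 to compound 3 (0.06 log units; within the scatter). For the measured compounds named here, that step changes the group on the sulfonyl sulfur, not the group on the aromatic carbon that is changed in compound 4, so it does not bear directly on the new step; it shows only that one such single swap left this assay unmoved. Going by the values given here, no measured pair speaks to the exchange of a 2-cyanophenyl for a 4-methylphenyl here.

Among the compounds with values here, with no direct precedent, compound 4 is expected to remain close to compound 1, with an estimated step of a 1.0-fold lower number from compound 1 to compound 4 (0.01 log units; within the scatter). For compound 4 the estimated value in this assay is 9000 nM, within a range from 3500 nM to 23000 nM.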

Compound 4, half-maximal cytotoxic concentration: 7910 nM
The estimate for compound 4 lay 1.1-fold (0.06 log units) above the measured number; low and high end bracket the measured number.
By their numbers in this assay, from the lowest: compounds 4 and 1 (each within the scatter of the next); then compounds 3 and 2 (each within the scatter of the next).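

In this assay, putting 4-methylphenyl in place of 2-cyanophenyl gives a 1.2-fold lower number from compound 1 to compound 4 (0.07 log units; within the scatter) and stays within the usual scatter of repeated measurements. At this place, para to a large group on the aromatic ring, the nitrile and its hydrogen-bond acceptor can therefore be exchanged for a methyl-bearing ring with no change in this test that can be told from that scatter. Nothing measured here explains why the number holds steady.

Still open, from the compounds shown here alone, is whether an amine or a carboxylic acid on the same aromatic ring, or a longer chain such as butyl in place of the methyl, would also leave the number unmoved. Going by these compounds, the same exchange also remains untested with a different group on the sulfonyl sulfur.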